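The compounds below may be only part of what the source reports. "The series", "measured", "known", "first", "only" and "open" are said of these compounds alone.

Compound 3, `CSc1cccc2c1c(O)c(C(=O)N(C)c1ccccc1)c(=O)n2C`, is the compound of this set giving the highest number in a functional assay on the whole organism for inhibition, with Mus musculus as the target, at a dose of 1 mg/kg by the oral route; a lower number here means less inhibition, a higher number more inhibition at the dose given (going by the name of the read-out): compound 3 gives 100%, while compound 2, `CCN(C(=O)c1c(O)c2c(Br)cccc2n(C)c1=O)c1ccccc1`, gives 95%, a number within the scatter, and compound 1, `CCN(C(=O)c1c(O)c2c(C)cccc2n(C)c1=O)c1ccccc1`, gives 65%, a number beyond it. Compound 4, `CCN(C(=O)c1c(O)c2c(SC)cccc2n(C)c1=O)c1ccccc1`, differs from compound 3 by methyl in place of hydrogen on a saturated chain carbon bound to an amide-type nitrogen. For the measured compounds named here, the one measured step, a number 30 percentage points higher from compound 1 to compound 2 (beyond the scatter), concerns a bromo for a methyl on an aromatic carbon, not the carbon bound to the amide-type nitrogen, so no measured step bears on this change. With compound 3 already near the top of the scale, the step is expected to be none beyond the scatter, a number 5 percentage points lower from compound 3 to compound 4 (within the scatter). Compound 4 is therefore estimated at 95%, between 80% and 100%.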

Compound 4, a percentage reported as inhibition, in the whole organism at one dose (the size of the read-out at that dose, not a potency): 73%
Compound 4: the middle estimate sits 22 percentage points above what was measured; the whole stated range lies above it.
By their numbers in this assay, from the lowest: compounds 1 and 4 (each within the scatter of the next); then compounds 2 and 3 (each within the scatter of the next).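

For the compounds shown here, the methyl to ethyl change, on a saturated chain carbon bound to an amide-type nitrogen, is the first change measured at this place, and in this assay it gives a number 27 percentage points lower from compound 3 to compound 4 (beyond the scatter), so this place matters for the read-out. With ethyl kept, methylsulfanyl in place of bromo gives a number 22 percentage points lower from compound 2 to compound 4 (beyond the scatter), whereas methylsulfanyl in place of methyl gives a number 8 percentage points higher from compound 1 to compound 4 (within the scatter). Nothing measured here accounts for these steps.

From the compounds shown here alone, whether a propyl chain at this place would lower the number further stays open. So does whether methyl to ethyl acts alike with bromo on the aromatic carbon.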